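Alkoxy chain length and cell toxicity in the series

The source may report more compounds than this note shows. Statements on the series, on what has been measured and on what is new or still open speak of the compounds shown alone.

Compound 1 `Cc1cc(C)cc(NC(=O)COc2cc(C)nc3ccc(F)cc23)c1` is the only fully numbered point: in a toxicity assay on HepG2 cells (Homo sapiens) for inhibition, read by CellTiter-Glo, with a stated time of 48 h (on this read-out higher numbers stand for weaker inhibition and lower numbers for stronger inhibition), compound 1 gives 63100 nM. Compound 2 `CCOc1ccc2nc(C)cc(OCC(=O)Nc3cc(C)cc(C)c3)c2c1` reaches only a limit of the assay, > 100000 nM, as shown by the limit of > 100000 nM in this assay, at which 1 of the 2 values shown sits. Among the measured compounds shown here, the single measured step, an at least 1.5-fold higher number from compound 1 to compound 2 (0.19 log units; that floor lies within the scatter), is therefore itself open-ended. For the measured compounds named here, compound 3 `Cc1cc(C)cc(NC(=O)COc2cc(C)nc3ccc(OCc4ccccc4)cc23)c1` carries phenyl in place of methyl on a saturated chain carbon bound to an oxygen on an aromatic ring; no measured step covers an alkoxy chain grown past ethoxy, so no direction can be read from the data. Compound 3 is expected to remain near the limit, at 100000 nM with a range of 30000 nM to 300000 nM. The expected step from compound 2 is a number no higher from compound 2 to compound 3 (the limit leaves the size open), within the scatter.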

Compound 3, half-maximal inhibitory concentration: > 100000 nM
Compound 3 ended at the assay's limit; the forecaster's own chance of this, stated with the estimate: 60%; the middle value lies on the limit itself.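

Benzyloxy in place of ethoxy keeps this position at the limit in this assay and gives no number inside the range of the assay, so a six-membered aromatic ring here shows no readable gain in toxicity. Among the compounds shown here, the step between the two limits cannot be read, and an at least 1.5-fold higher number from compound 1 to compound 3 (0.19 log units; that floor lies within the scatter) is the only readable step for this change of group. The limit now covers most of the compounds shown: the limit of > 100000 nM in this assay, at which 2 of the 3 values shown sit.

As far as these compounds go, whether an amine or a carboxylic acid on this chain would give a number inside the range stays open.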